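A few compounds are considered here, and "the series" means these few. Any claim that something is new, unique, unknown or untested is made for them only; others in the source may bear on it.

In a functional assay on MCF7 cells (Homo sapiens) for cytotoxicity, read by fluorescence, with a stated time of 72 h (on this read-out higher numbers stand for weaker inhibition and lower numbers for stronger inhibition), compound 1 `CSc1nc(NCc2ccc(-c3ccccn3)cc2)c2[nH]nc(C(C)C)c2n1` gives 819 nM, compound 2 `CC(C)c1n[nH]c2c(NCc3ccc(-c4ccccn4)cc3)nc(NCCO)nc12` gives 51 nM and compound 3 `CC(C)c1n[nH]c2c(NCc3ccc(-c4ccccn4)cc3)nc(NCCN)nc12` gives 62 nM. Compound 3 thus stands far lower than compound 1 and within the scatter of compound 2. Compound 4 `CC(C)c1n[nH]c2c(NCc3ccc(-c4ccccn4)cc3)nc(NCC(N)CO)nc12` has hydroxymethyl in place of hydrogen on a saturated chain carbon bound to an amine nitrogen and a saturated chain carbon. The large steps, a 16-fold lower number from compound 1 to compound 2 (1.21 log units; beyond the scatter) and a 13-fold lower number from compound 1 to compound 3 (1.12 log units; beyond the scatter), replaced methylsulfanyl on an aromatic carbon, which this change leaves alone. The closer guide is amino in place of hydroxy on a saturated chain carbon, which gave a 1.2-fold higher number from compound 2 to compound 3 (0.08 log units; within the scatter). In this assay the expected change is therefore a 1.2-fold lower number from compound 3 to compound 4 (0.09 log units; within the scatter), nothing beyond the scatter. Compound 4 is estimated at 50 nM, with an expected range of 20 nM to 130 nM.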

Compound 4, half-maximal inhibitory concentration: 310 nM
For compound 4 the middle estimate is 6.2-fold (0.79 log units) below the measured one; the whole stated range lies below it.
By their numbers in this assay, from the lowest: compounds 2 and 3 (each within the scatter of the next); then compound 4; then compound 1.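

In this assay this carbon does not tolerate the added hydroxymethyl the way the earlier swap of hydroxy for amino suggested: the change gives a 5.0-fold higher number from compound 3 to compound 4 (0.70 log units; beyond the scatter), and the chain carrying both amino and hydroxy also falls behind the chain with hydroxy alone, with a 6.1-fold higher number from compound 2 to compound 4 (0.78 log units; beyond the scatter). The combined chain still improves on methylsulfanyl, with a 2.6-fold lower number from compound 1 to compound 4 (0.42 log units; beyond the scatter), so part of the gain remains. Nothing measured here explains the loss. Open, on these data alone, is how a plain methyl or an aminomethyl in place of that hydrogen would read, and whether a longer chain would recover the lost ground.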